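The compounds below may be only part of what the source reports. "The series", "measured", "known", "first", "only" and "open" are said of these compounds alone.

Measured so far in a functional assay on COLO 205 cells (Homo sapiens) for inhibition, read by sulforhodamine B assay, tested at 100 uM; on this read-out higher numbers stand for more inhibition of growth at the one concentration tested and lower numbers for less inhibition of growth:
compound 1 `COc1cc(C2CC(c3ccc(OCc4cn(Cc5ccc([N+](=O)[O-])cc5)nn4)cc3)=NN2C(C)=O)ccc1Oc1cn(Cc2ccc([N+](=O)[O-])cc2)nn1` — 51%
compound 2 `COc1cc(C2CC(c3ccc([N+](=O)[O-])cc3)=NN2C(C)=O)ccc1OCc1cn(Cc2ccc([N+](=O)[O-])cc2)nn1` — 85%
compound 3 `COc1cc(C2CC(c3ccc(Br)cc3)=NN2C(C)=O)ccc1OCc1cn(Cc2ccc([N+](=O)[O-])cc2)nn1` — 47%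

Compound 3 stands lowest of the three numbers in this assay; its gap to compound 1 lies within the scatter, its gap to compound 2 beyond it. Going by the values given here, the only step at the same aromatic carbon is a number 38 percentage points lower from compound 2 to compound 3 (beyond the scatter), a large fall on going from nitro to bromo.

Compound 4 `COc1cc(C2CC(c3ccccc3)=NN2C(C)=O)ccc1OCc1cn(Cc2ccc([N+](=O)[O-])cc2)nn1` differs from compound 3 by hydrogen in place of bromo on an aromatic carbon. No measured step removes a group at this position altogether, so the one step shown can only suggest that this carbon matters, not the size of the change here. The expected step for compound 4 is therefore a number 5 percentage points lower from compound 3 to compound 4 (within the scatter), within the scatter. Compound 4 is estimated at 42%, range 25% to 60%.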

Compound 4, percent growth inhibition at one concentration: 11%
The estimate for compound 4 lay 31 percentage points above the measured number; measured number below the stated range.
By their numbers in this assay, from the lowest: compound 4; then compounds 3 and 1 (each within the scatter of the next); then compound 2.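

Bromo on this aromatic carbon contributes clearly to growth inhibition: in this assay the change from 4-bromophenyl to phenyl gives a number 36 percentage points lower from compound 3 to compound 4 (beyond the scatter), so the loss at this carbon does not stop at the earlier fall from nitro to bromo. Taken from nitro directly, hydrogen gives a number 74 percentage points lower from compound 2 to compound 4 (beyond the scatter), which orders the three groups as nitro, bromo, hydrogen, each step beyond the scatter.

Where an amine, a carboxylic acid or a methoxy group would fall in that order remains open. Nothing available accounts for the order.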